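This account rests on a few compounds, and the source may have more. Where it says the series, first, only, none or still open, it means among the compounds named here.

Measured so far in a physicochemical assay for lipophilicity, at pH 7.4; on this read-out lower numbers stand for lower lipophilicity and higher numbers for higher lipophilicity:

- compound 1, `CCc1ccc(N(CC(C)C)S(=O)(=O)c2ccc(OCC3CCOCC3)c(CN)c2)cc1`, gives 3.25
- compound 2, `CC(C)CN(c1cccc(F)c1)S(=O)(=O)c1ccc2c(c1)C(O)CC(C1CCOCC1)O2`, gives 3.39
- compound 3, `CCc1ccc(N(CC(C)C)S(=O)(=O)c2ccc3c(c2)C(O)C[C@@H](C2CCOCC2)O3)cc1`, gives 4.12

Compound 2 has the second highest of these three numbers. Its nearest neighbour is compound 1, whose value lies within the scatter of repeated measurements, so the two cannot be told apart on this read-out. Compound 3 stands furthest away, with a value beyond the scatter above compound 2.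

The piece follows a single change from compound 2 to an unmeasured compound, compound 4, `CC(C)CN(c1ccc(F)cc1F)S(=O)(=O)c1ccc2c(c1)C(O)CC(C1CCOCC1)O2`. The change is 2,4-difluorophenyl in place of 3-fluorophenyl on a sulfonamide nitrogen. Nothing among the measured compounds shows the same change, so no shown step can be borrowed; the expectation rests on the change itself being small in size. A small step upward in this assay is expected, most likely staying within the scatter of the measurement. Compound 4 is therefore estimated at 3.55, with a range from 3.25 to 3.85. The step this expectation means, a number 0.16 log units higher from compound 2 to compound 4 (within the scatter), is expected to be modest.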

Compound 4, distribution coefficient: 3.53
Beside the measured number, compound 4's estimate is 0.02 log units above it; the measured number falls inside the stated range.
By their numbers in this assay, from the lowest: compounds 1, 2 and 4 (each within the scatter of the next); then compound 3.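

In this assay, 2,4-difluorophenyl in place of 3-fluorophenyl on the sulfonamide nitrogen gives a number 0.14 log units higher from compound 2 to compound 4 (within the scatter) and so leaves the two compounds indistinguishable on this read-out. This is the first step shown that changes this group alone, and it shows that this position can take a second fluorine with no clear shift in the number. Nothing measured here offers a reason for the size of this step.

Still open, from the compounds shown here alone, is whether a group of another kind on the phenyl ring, such as a methoxy group, a nitrile or a carboxylic acid in place of fluorine, would carry the number beyond the scatter. Equally open, going by these compounds, is what a longer chain in place of the present saturated chain on the same sulfonamide nitrogen would do.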